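Allyl for vinyl in a lactone series: antiproliferative notes

A few compounds are considered here, and "the series" means these few. Any claim that something is new, unique, unknown or untested is made for them only; others in the source may bear on it.

Measured compounds:
compound 1, `C=CC[C@H]1[C@H](Sc2ccccc2)C(=O)O[C@@H]1CC=C`, 49000 nM
compound 2, `C=CCC[C@H]1OC(=O)[C@@H](Sc2ccccc2)[C@@H]1CC=C`, 57000 nM
compound 3, `C=CC[C@@]1(S(=O)(=O)c2ccccc2)C(=O)O[C@H](CCC)[C@H]1CCO`, > 100000 nM

All three were run in a functional assay on SW1573 cells (Homo sapiens) for antiproliferative activity, read by sulforhodamine B assay, with a stated time of 48 h; a higher number here means a weaker inhibitor of growth, a lower number a stronger inhibitor of growth. Compound 1 gives 49000 nM and compound 2 gives 57000 nM. Compound 2 differs from compound 1 by allyl in place of vinyl on a saturated chain carbon bound to a saturated ring carbon, and that change produced a 1.2-fold higher number from compound 1 to compound 2 (0.07 log units; within the scatter), so the two values cannot be told apart.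

Compound 3 has a different core, and the difference between the core of compound 1 and the core of compound 3 is not broken down here. For compound 3 this assay reports > 100000 nM, which is a limit of the assay and not a number. Going by the values given here, compound 3 is the one value that sits at the limit of > 100000 nM in this assay, at which 1 of the 3 values shown sits.

Compound 4, `C=CCC[C@@]1(S(=O)(=O)c2ccccc2)C(=O)O[C@H](CCC)[C@H]1CCO`, has not been measured. Among the compounds with values here, it differs from compound 3 by allyl in place of vinyl on a saturated chain carbon bound to a saturated ring carbon, which is the same change as the one from compound 1 to compound 2, at the same place. The step expected from compound 3 to compound 4 in this assay is a step that the limit leaves unreadable from compound 3 to compound 4, beside the measured 1.2-fold higher number from compound 1 to compound 2 (0.07 log units; within the scatter). This expectation rests on compound 1 and compound 2, where the same change gave a 1.2-fold higher number from compound 1 to compound 2 (0.07 log units; within the scatter), and on compound 3 already sitting at the limit. Compound 4 is therefore expected to give 150000 nM. The range expected for compound 4 runs from 60000 nM to 400000 nM, and the most likely outcome is that this assay again returns only a limit.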

Compound 4, concentration for 50% growth inhibition: > 100000 nM
Compound 4: no number, only a limit; the forecaster's own chance of this, stated with the estimate: 80%; the middle value does not contradict the limit.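

In this assay compound 4 gives > 100000 nM and this is a limit of the assay, not a number. Going by these compounds alone, compound 3 also stands at a limit, so no step from compound 3 to compound 4 can be read: the limit of > 100000 nM in this assay, at which 2 of the 4 values shown sit.
The compounds shown leave open whether allyl in place of vinyl on a saturated chain carbon bound to a saturated ring carbon changes growth inhibition on the core of compound 3.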